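The source may report more compounds than this note shows. Statements on the series, on what has been measured and on what is new or still open speak of the compounds shown alone.

Measured so far:
- compound 1 `O=C1NC(=O)/C(=C/C2=Cc3ccccc3OC2)S1`: 99400 nM in a functional assay on MCF7 cells (Homo sapiens) for antiproliferative activity, read by MTT assay, with a stated time of 72 h; a higher number here means a weaker inhibitor, a lower number a stronger inhibitor
- compound 2 `CN1C(=O)S/C(=C\C2=Cc3ccccc3OC2)C1=O`: for compound 2 this assay reports only a limit, > 100000 nM
- compound 3 `CC1Oc2ccc(Br)cc2C=C1/C=C1\SC(=O)NC1=O`: 67600 nM in this assay

Compound 2 comes from compound 1 by a single change, (methyl in place of hydrogen on an amide-type nitrogen in a ring). The step it made is a number no lower from compound 1 to compound 2 (the limit leaves the size open), and its size stays hidden because of the limit of > 100000 nM in this assay, at which 1 of the 3 values shown sits. Compound 3 shares this ring with its two carbonyl groups but carries a different core; how the two cores differ is not broken down here. The values of compound 3 and compound 1 sit within the usual scatter of each other, so no order between them can be read.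

Compound 4 `CC1Oc2ccc(Br)cc2C=C1/C=C1\SC(=O)N(C)C1=O` is to be measured in this assay. Among the measured compounds shown here, it differs from compound 3 by methyl in place of hydrogen on an amide-type nitrogen in a ring, the same change as the one from compound 1 to compound 2, at the same place. As far as these compounds go, the step I expect from compound 3 to compound 4 is a 1.9-fold higher number from compound 3 to compound 4 (0.28 log units; within the scatter), a weakening, and it rests on a number no lower from compound 1 to compound 2 (the limit leaves the size open) from compound 1 to compound 2, whose exact size is unknown. For compound 4 I estimate 130000 nM, likely between 60000 nM and 300000 nM.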

Compound 4, half-maximal inhibitory concentration: > 50000 nM
Compound 4: a limit, no number (the forecaster's own chance of this, stated with the estimate: 55%); the middle value does not contradict the limit.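

No size or direction can be read for the step between compound 3 and compound 4, because compound 4 gives only a limit and not a number: the limit of > 50000 nM in this assay, at which 1 of the 4 values shown sits.

The compounds shown leave open how large the change from the amide hydrogen to methyl is on either core, and whether the two cores respond alike.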